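This account rests on a few compounds, and the source may have more. Where it says the series, first, only, none or still open, it means among the compounds named here.

Compound 3, `C/C=C/C(=O)Nc1ccc(Cn2nc(-c3ccc(Oc4ccccc4)cc3)cc2CO)cc1`, reaches only a limit in a functional assay on JeKo-1 cells (Homo sapiens) for inhibition, read by luminescence and CellTiter-Glo, with a stated time of 72 h (a lower number here means a stronger inhibitor, a higher number a weaker inhibitor), where compound 3 gives > 60000 nM. Compound 1, `C=CC(=O)Nc1ccc(Cn2nc(-c3ccc(Oc4ccccc4)cc3)cc2C(=O)O)cc1`, likewise gives a limit of > 60000 nM. Among the compounds with values here, compound 2, `C=CC(=O)Nc1ccc(Cn2nc(-c3ccc(Oc4ccccc4)cc3)cc2C(=O)OCC)cc1`, gives 10900 nM, so that the step of an at least 5.5-fold lower number from compound 1 to compound 2 (0.74 log units; beyond the scatter) is the one measured step beyond the scatter, and the limit of > 60000 nM in this assay, at which 2 of the 3 values shown sit, marks where two of the three values sit. Compound 4, `C=CC(=O)Nc1ccc(Cn2nc(-c3ccc(Oc4ccccc4)cc3)cc2CO)cc1`, differs from compound 3 by vinyl in place of prop-1-en-1-yl on a carbonyl carbon. Within the data shown here, no measured pair covers this change at the amide, and the measured step concerns a different position, so it gives no direct guidance for this assay. Compound 4 is therefore expected to give about 20000 nM, within 3000 nM to 90000 nM, an estimated step of an at least 3.0-fold lower number from compound 3 to compound 4 (0.47 log units; beyond the scatter).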

Compound 4, half-maximal inhibitory concentration: 8000 nM
Compound 4: middle estimate off by 2.5-fold (0.40 log units), on the high side; the measured number falls inside the stated range.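

Within the data shown here, with hydroxymethyl held in place on the shared core, vinyl in place of prop-1-en-1-yl on the carbonyl carbon moves the reading in this assay off its limit (an at least 7.5-fold lower number from compound 3 to compound 4 (0.87 log units; beyond the scatter)), a sensitivity at this position that no earlier pair could show. With vinyl fixed, hydroxymethyl and ethoxycarbonyl on the aromatic carbon cannot be told apart (a 1.4-fold lower number from compound 2 to compound 4 (0.13 log units; within the scatter)), whereas carboxy stands clearly apart from hydroxymethyl (an at least 7.5-fold lower number from compound 1 to compound 4 (0.87 log units; beyond the scatter)).

As far as these compounds go, whether the vinyl gain holds with ethoxycarbonyl on the aromatic carbon remains open. Also open, from the compounds shown here alone, is how a saturated propanoyl amide, or an amine on that aromatic carbon, would read in this assay.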